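Swapping an amine for an ether on a quinoline-carboxamide core

The source may report more compounds than this note shows. Statements on the series, on what has been measured and on what is new or still open speak of the compounds shown alone.

Compound 1 `NC(=O)c1cnc2ccc(-c3cccnc3)cc2c1NC1CCCC1` is one of three compounds tested in an assay on HT-29 cells for inhibition of Serine-protein kinase ATM (Homo sapiens), read by fluorescence, with a stated time of 1 h (on this read-out higher numbers stand for weaker inhibition and lower numbers for stronger inhibition), where compound 1 gives 137 nM. That is the second highest of the three numbers. Compound 2 `CCC(CC)CNc1c(C(N)=O)cnc2ccc(-c3ccc(COC)cc3)cc12` gives 373 nM in this assay, and compound 3 `CCC(CC)CNc1c(C(N)=O)cnc2ccc(-c3ccc(COC)nc3)cc12` gives 45 nM. Going by the values given here, the only single-point step among the measured compounds is an 8.3-fold lower number from compound 2 to compound 3 (0.92 log units; beyond the scatter), which concerns the aryl group attached to the shared core and not the side chain on the carboxamide-bearing ring.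

Compound 4 `CCC(CC)COc1c(C(N)=O)cnc2ccc(-c3cccnc3)cc12` differs from compound 1 in a different place: 2-ethylbutoxy in place of cyclopentylamino on an aromatic carbon. The ring-bearing amine is gone, and with it the hydrogen-bond donor that it carried; a branched chain joined through an oxygen takes its place. Among the compounds with values here, no measured step addresses that kind of exchange, so the expectation rests on the value of compound 1 alone, with no direct guide to direction or size. Compounds 2 and 3 also carry a branched chain at this position, though linked through nitrogen, and their values are the highest and lowest of the three, which gives no clear lean.

The expected step for compound 4 is a 2.9-fold higher number from compound 1 to compound 4 (0.47 log units; beyond the scatter), toward a weaker result in this assay.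

Compound 4 is therefore estimated at 400 nM in this assay, within a range from 80 nM to 2500 nM.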

Compound 4, half-maximal inhibitory concentration: > 30000 nM
Compound 4: no number, only a limit; the forecaster's own chance of this, stated with the estimate: 5%; at least 75-fold (1.87 log units) between middle value and limit.
By their numbers in this assay, from the lowest: compound 3; then compound 1; then compound 2. At a limit, above all of these: compound 4.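

In this assay compound 4 gives no number, only a limit of the read-out: the limit of > 30000 nM in this assay, at which 1 of the 4 values shown sits.

Even so, the exchange of cyclopentylamino for 2-ethylbutoxy, ortho to a carbamoyl group, can be read as a minimum, an at least 210-fold higher number from compound 1 to compound 4 (2.34 log units; beyond the scatter), and that minimum already exceeds the aryl change seen earlier, an 8.3-fold lower number from compound 2 to compound 3 (0.92 log units; beyond the scatter), so this position tolerates far less change than the first three compounds could reveal. The step also shows that the hydrogen-bond donor of cyclopentylamino, the ring and the nitrogen link cannot be swapped together for an open chain joined through oxygen without a large rise in the number on this read-out.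

The compounds shown leave open which part of the exchange carries the loss, since the link atom and the ring change in the same step: cyclopentyloxy on the core of compound 1 would change the link atom alone, and 2-ethylbutylamino would change the ring alone. How far the true value of compound 4 lies past the limit, and why the exchange costs so much, also stays unknown.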